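This account rests on a few compounds, and the source may have more. Where it says the series, first, only, none or still open, it means among the compounds named here.

Measured in a functional assay on EBC-1 cells (Homo sapiens) for antiproliferative activity, with a stated time of 72 h; a lower number here means a stronger inhibitor, a higher number a weaker inhibitor:
- compound 1 `CN(C)CCNC(=O)c1ccc(-c2cc(F)c3ncc(Cc4ccc5ncccc5c4)n3c2)cc1F`: 49 nM
- compound 2 `O=C(NC1CCCNC1)c1ccc(-c2cc(F)c3ncc(Cc4ccc5ncccc5c4)n3c2)cc1F`: 138 nM
- compound 3 `O=C(NCc1ccccn1)c1ccc(-c2cc(F)c3ncc(Cc4ccc5ncccc5c4)n3c2)cc1F`: 5550 nM

Compound 3 is the weakest of the three, with a 110-fold higher number from compound 1 to compound 3 (2.05 log units; beyond the scatter) and a 40-fold higher number from compound 2 to compound 3 (1.60 log units; beyond the scatter), both large and beyond the scatter. The two amines differ far less, with a 2.8-fold higher number from compound 1 to compound 2 (0.45 log units; beyond the scatter), a modest step.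

The next compound is compound 4 `O=C(NC1CCOCC1)c1ccc(-c2cc(F)c3ncc(Cc4ccc5ncccc5c4)n3c2)cc1F`, with oxan-4-yl in place of (pyridin-2-yl)methyl on an amide-type nitrogen. The closest guide is the step from compound 2, since its piperidin-3-yl, like oxan-4-yl, is a non-aromatic group standing directly on that nitrogen. Read backwards, a 40-fold higher number from compound 2 to compound 3 (1.60 log units; beyond the scatter) points to a lower number for compound 4 in this assay. Among the compounds with values here, no measured compound carries oxan-4-yl, however, so only part of that gain is expected, and the step is expected to be sizeable but smaller.

The expected change is a 7.9-fold lower number from compound 3 to compound 4 (0.90 log units; beyond the scatter).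

For compound 4 the estimated value is 700 nM, with an expected range of 130 nM to 3500 nM.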

Compound 4, half-maximal inhibitory concentration: 70.5 nM
Beside the measured number, compound 4's estimate is 9.9-fold (1.00 log units) above it; the measured number lies below the stated range.
By their numbers in this assay, from the lowest: compounds 1, 4 and 2 (each within the scatter of the next, the first and the last beyond it); then compound 3.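

The large step of a 79-fold lower number from compound 3 to compound 4 (1.90 log units; beyond the scatter) in this assay shows that this amide-type nitrogen can carry a non-aromatic ring with no amine and still avoid the weak result seen with (pyridin-2-yl)methyl. An amine in the side chain is therefore not needed for compound 4 to match the amine-bearing compounds, as the steps of a 2.0-fold lower number from compound 2 to compound 4 (0.29 log units; within the scatter) and a 1.4-fold higher number from compound 1 to compound 4 (0.16 log units; within the scatter) both lie within the scatter. Among these four compounds, only compound 3 stands apart, and nothing given here explains why.

The compounds shown leave open whether the loss in compound 3 goes with its aromatic ring or with the methylene link, a question that (oxan-4-yl)methyl on the same nitrogen would address. They also leave open how a carboxylic acid or a longer chain at this position would behave.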